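Swapping Hydroxy for Methoxy on a Measured Inhibitor

This account rests on a few compounds, and the source may have more. Where it says the series, first, only, none or still open, it means among the compounds named here.

Measured so far in a functional assay for inhibition, with Homo sapiens as the target; a higher number here means a weaker inhibitor, a lower number a stronger inhibitor:

- compound 1 `CCC1CS(=O)(=O)c2cc(C(=O)N=C(N)N)c(C)cc21` gives 78 nM
- compound 2 `Cc1cc2c(cc1C(=O)N=C(N)N)S(=O)(=O)C/C2=N\O` gives 197 nM

Of these two, compound 2 carries the higher number and so is the weaker inhibitor in this assay, and its gap to compound 1 lies beyond the usual scatter of repeated measurements.

Compound 3 `CO/N=C1\CS(=O)(=O)c2cc(C(=O)N=C(N)N)c(C)cc21` has not yet been measured. It differs from compound 2 in one place, by the change methyl in place of hydrogen on an oxygen that puts methyl in place of hydrogen on an oxygen, turning hydroxy into methoxy. The two measured compounds do not differ in just one place, so the data offer no direct guide to what such a change does. The addition is small, so the expectation, starting from compound 2 at 197 nM, is no step beyond the scatter. The estimated step is a 1.2-fold lower number from compound 2 to compound 3 (0.06 log units; within the scatter) in this reading. For compound 3 the expected value is 170 nM, with 70 nM to 420 nM as its estimated range.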

Compound 3, half-maximal inhibitory concentration: 521 nM
Compound 3: middle estimate off by 3.1-fold (0.49 log units), on the low side, and the stated range ends below it.
By their numbers in this assay, from the lowest: compound 1; then compound 2; then compound 3.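

Within the data shown here, putting methyl in place of hydrogen on this oxygen, whose other neighbour is a double-bonded nitrogen, is the first change that can be read on its own, and in this assay it gives a 2.6-fold higher number from compound 2 to compound 3 (0.42 log units; beyond the scatter) and so makes the inhibitor weaker. The position therefore responds to very little: one added carbon, turning hydroxy into methoxy, is enough to produce a step beyond the usual scatter of repeated measurements, something the earlier pair could not show since its members differ in more than one place. Nothing measured here speaks to why the added methyl has this effect.

The compounds shown leave open whether a longer chain on this oxygen, such as ethyl or benzyl, or a chain ending in an amine or a carboxylic acid, would move the number further in the same direction or bring it back. A single step also cannot say whether methyl in place of hydrogen on an oxygen would have a similar effect on a different core.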